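Ring size at the chain amine, compound 3 to compound 4

The source may hold more compounds than are shown below. What is called first, only, known or untested is meant among the compounds shown, and "the series" means these compounds.

In a functional assay on BCG823 cells (Homo sapiens) for antiproliferative activity, read by MTT assay, with a stated time of 48 h (on this read-out lower numbers stand for stronger inhibition and higher numbers for weaker inhibition), compound 1 `CN1CCN(CCCCOc2c(O)cc3oc(-c4ccccc4)cc(=O)c3c2O)CC1` gives 82900 nM, compound 2 `CCN(CC)CCCCOc1c(OCc2ccccc2)cc2oc(-c3ccccc3)cc(=O)c2c1O` gives 4200 nM, and compound 3 `COc1cc2oc(-c3ccccc3)cc(=O)c2c(O)c1OCCCCN1CCCC1` gives 10600 nM. Compound 3 therefore holds the second highest of the three numbers, standing nearer to compound 2 than to compound 1. Compound 4 `COc1cc2oc(-c3ccccc3)cc(=O)c2c(O)c1OCCCCN1CCCCC1` differs from compound 3 in one place: piperidin-1-yl in place of pyrrolidin-1-yl on a saturated chain carbon, four bonds along the chain from an oxygen on an aromatic ring. Going by the values given here, no step between measured compounds bears on this change, so nothing measured here gives its size. The expectation is that the change from compound 3 to compound 4 stays within the usual scatter of this assay, with no clear direction. On that basis compound 4 is estimated at 9500 nM, within 4500 nM to 20000 nM. This estimate means that a step of a 1.1-fold lower number from compound 3 to compound 4 (0.05 log units; within the scatter) is expected.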

Compound 4, half-maximal inhibitory concentration: 21900 nM
Estimate against measurement, compound 4: 2.3-fold (0.36 log units) below; the whole stated range lies below it.
By their numbers in this assay, from the lowest: compound 2; then compound 3; then compound 4; then compound 1.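

In this assay, going by these compounds alone, the series now has its one readable single-place step: piperidin-1-yl in place of pyrrolidin-1-yl gives a 2.1-fold higher number from compound 3 to compound 4 (0.32 log units; beyond the scatter), modest but beyond the scatter. The amine ring on this saturated chain carbon is therefore not a free choice, and the six-membered ring goes with weaker inhibition than the five-membered one on the core of compound 3. No measurement at hand accounts for the step. Open: whether azepan-1-yl or morpholin-4-yl at the same chain end continues this direction, and whether a longer chain preserves the difference between the two rings.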